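This account rests on a few compounds, and the source may have more. Where it says the series, first, only, none or still open, it means among the compounds named here.

Of the compounds shown here, two have so far been tested in an ADME assay on HEK293 cells (Homo sapiens) for inhibition, read by MTT assay, with stated times of 18 h and 4 h; a lower number here means a stronger inhibitor, a higher number a weaker inhibitor. Compound 1, `CCCCCCCCCCCCCCCCOP(=O)(O)OCCSC(=S)N1CCCCC1`, carries a long chain. In this assay compound 1 gives > 100000 nM, which is a limit of the assay rather than a measured number. Compound 2, `CCCOP(=O)(O)OCCSC(=S)N1CCCC1`, carries a much shorter chain. In this assay compound 2 gives > 100000 nM, again only a limit. Both results share (the limit of > 100000 nM in this assay, at which 2 of the 2 values shown sit), so neither compound can be ranked against the other, and compound 2 stands exactly where compound 1 stands. Compound 3, `CCCCCCCCCCOP(=O)(O)OCCSC(=S)N1CCCC1`, has not yet been measured. It differs from compound 2 by heptyl in place of hydrogen on a saturated chain carbon, three bonds along the chain from an oxygen on an unsaturated carbon. Among the measured compounds shown here, no measured step resembles this change, so no direction can be drawn from the data. For compound 3 the expected step is a step that the limit leaves unreadable from compound 2 to compound 3, within the scatter. Compound 3 is estimated to give 150000 nM in this assay, with a range from 40000 nM to 600000 nM, most likely reported once more only as a limit.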

Compound 3, half-maximal inhibitory concentration: > 100000 nM
Compound 3 ended at the assay's limit; the forecaster's own chance of this, stated with the estimate: 80%; the middle value lies beyond the limit too.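

No step can be read from compound 2 to compound 3, because both results are limits rather than numbers: the limit of > 100000 nM in this assay, at which 3 of the 3 values shown sit. The compounds shown leave open what true value each has in this assay, and so whether heptyl in place of hydrogen changes anything.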